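The source may hold more compounds than are shown below. What is called first, only, known or untested is meant among the compounds shown, and "the series" means these compounds.

The measured compounds and their values in an ADME assay on HepG2 cells (Homo sapiens) for cytotoxicity, read by MTT assay, with a stated time of 72 h; a lower number here means that less compound is tolerated, a higher number that more compound is tolerated:

Compound 1 `CC1(c2ccc(-c3ccco3)cc2)CC(S(=O)(=O)c2ccc(F)cc2)=C(c2ccc(/C(N)=N\O)cc2)O1` gives 7010 nM in this assay.
Compound 2 `CC1(c2ccccc2)CC(S(=O)(=O)c2ccc(F)cc2)=C(c2ccc(/C(N)=N\O)cc2)O1` gives 68300 nM in this assay.
Compound 3 `CC1(c2ccc(Cl)cc2)CC(S(=O)(=O)c2ccc(F)cc2)=C(c2ccc(/C(N)=N\O)cc2)O1` gives 61400 nM in this assay.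

Compound 3 stands second highest of the three numbers. Its nearest neighbour is compound 2, and the difference between them, a 1.1-fold lower number from compound 2 to compound 3 (0.05 log units; within the scatter), lies within the scatter. Its furthest neighbour is compound 1, reached by an 8.8-fold higher number from compound 1 to compound 3 (0.94 log units; beyond the scatter), a step beyond the scatter.

The new compound 4 `CC1(c2ccc(-c3cccc([N+](=O)[O-])c3)cc2)CC(S(=O)(=O)c2ccc(F)cc2)=C(c2ccc(/C(N)=N\O)cc2)O1` differs from compound 3 in one place: 3-nitrophenyl in place of chloro on an aromatic carbon. Among the compounds with values here, the steps that bear on this change are those where a ring replaces or leaves the same aromatic carbon. Going from compound 1 to compound 2, a 9.7-fold higher number from compound 1 to compound 2 (0.99 log units; beyond the scatter), and going from compound 1 to compound 3, an 8.8-fold higher number from compound 1 to compound 3 (0.94 log units; beyond the scatter), both show that the compound carrying a ring at this position gives the lower number, while hydrogen and chloro give about the same higher number. Compound 4 again carries a ring there, so a modest step downward, in the direction of compound 1, is expected for this assay, a 6.8-fold lower number from compound 3 to compound 4 (0.83 log units; beyond the scatter). Compound 4 is therefore estimated to give 9000 nM in this assay, within a range from 3000 nM to 30000 nM.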

Compound 4, half-maximal cytotoxic concentration: > 50000 nM
Compound 4 gave a limit, no number; the forecaster's own chance of this, stated with the estimate: 5%; at least 5.5-fold (0.74 log units) between middle value and limit.
By their numbers in this assay, from the lowest: compound 1; then compounds 3 and 2 (each within the scatter of the next).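

In this assay compound 4 ends in a limit of the assay, not a number: the limit of > 50000 nM in this assay, at which 1 of the 4 values shown sits. Even so, placing 3-nitrophenyl in place of furan-2-yl on this aromatic carbon gives an at least 7.1-fold higher number from compound 1 to compound 4 (0.85 log units; beyond the scatter), so carrying a ring here does not by itself go with the low number of compound 1, and which ring sits on this carbon makes a difference. From the compounds shown here alone, the steps from compound 2 and compound 3 to compound 4 cannot be read, so it stays unknown how compound 4 ranks against these two compounds, whose substituents are hydrogen and chloro.

With only two ring-bearing compounds in hand, the compounds shown do not tell whether the low number of compound 1 is specific to furan-2-yl or would also appear with other small aromatic rings, such as thiophene. They also leave open whether the nitro group in compound 4 matters at all, a question that a plain phenyl ring, or an amine in place of the nitro group, at this position would address.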